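Adding a phenyl to compound 3

This account rests on a few compounds, and the source may have more. Where it says the series, first, only, none or still open, it means among the compounds named here.

Compound 1 `COc1ccc(/C=C/c2cc(OC)cc(OC)c2/C=C/C(=O)c2ccc(Br)cc2)cc1` gives 8.3 ug/mL
Compound 2 `COc1ccc(/C=C/c2cc(OC)cc(OC)c2/C=C/C(=O)c2ccc(N)cc2)cc1` gives 3.8 ug/mL
Compound 3 `COc1ccc(/C=C/c2cc(OC)cc(OC)c2/C=C/C(=O)c2ccccc2)cc1` gives 3.9 ug/mL

These numbers come from a functional assay on A549 cells (Homo sapiens) for antiproliferative activity, read by MTT assay, with a stated time of 48 h (a higher number here means a weaker inhibitor, a lower number a stronger inhibitor), and the three compounds differ in one place only. Compound 3 carries hydrogen at that place and compound 2 carries amino. Their numbers cannot be told apart, with a 1.0-fold higher number from compound 2 to compound 3 (0.01 log units; within the scatter) as the whole gap. Compound 1 carries bromo and stands apart from both, with a 2.2-fold lower number from compound 1 to compound 2 (0.34 log units; beyond the scatter) and a 2.1-fold lower number from compound 1 to compound 3 (0.33 log units; beyond the scatter) as modest steps.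

The next compound, compound 4 `COc1ccc(/C=C/c2cc(OC)cc(OC)c2/C=C/C(=O)c2ccc(-c3ccccc3)cc2)cc1`, has phenyl in place of hydrogen on an aromatic carbon. The change is phenyl in place of hydrogen on an aromatic carbon and it turns phenyl to 4-phenylphenyl. The two measured replacements of hydrogen disagree, as amino leaves the number where it was while bromo goes with a higher one. Among the compounds with values here, no measured compound carries a ring at this place, so the guide is weak. Even so, a modest rise in this assay is the more cautious expectation, on the model of compound 1 at 8.3 ug/mL in this series. The expected change is a 1.5-fold higher number from compound 3 to compound 4 (0.19 log units; within the scatter) with a wide margin. The estimate for compound 4 is 6 ug/mL within an expected range from 2.5 ug/mL to 14 ug/mL in this assay.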

Compound 4, half-maximal inhibitory concentration: 4.6 ug/mL
Beside the measured number, compound 4's estimate is 1.3-fold (0.12 log units) above it; the range from low to high includes it.
By their numbers in this assay, from the lowest: compounds 2, 3, 4 and 1 (each within the scatter of the next, the first and the last beyond it).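

In this assay, a phenyl ring of six heavy atoms can stand on this aromatic carbon where compound 3 has only a hydrogen, with no clear effect on the number: both a 1.2-fold higher number from compound 3 to compound 4 (0.07 log units; within the scatter) and a 1.2-fold higher number from compound 2 to compound 4 (0.08 log units; within the scatter) lie within the scatter. The third step, a 1.8-fold lower number from compound 1 to compound 4 (0.26 log units; within the scatter), also lies within the scatter, so compound 4 cannot be separated from compound 1 either, even though compound 1 stands beyond the scatter from compound 2 and compound 3. This position therefore accepts a whole added ring without a step beyond the scatter from hydrogen, which bromo did produce, so among these four compounds the number does not simply follow the size of the group, and nothing available explains why.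

A saturated ring such as cyclohexyl or a nitrogen-containing ring such as pyridyl at this place would test whether the aromatic carbon ring itself matters. A carboxylic acid or a dimethylamino group on the outer end of the phenyl would show whether this added ring can carry further groups and still keep the number in the same range.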